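Carboxy amide chains: from compound 3 to compound 4

The source may report more compounds than this note shows. Statements on the series, on what has been measured and on what is new or still open speak of the compounds shown alone.

Values measured in a functional assay on PC-3 cells (Homo sapiens) for antiproliferative activity, read by MTT assay, with a stated time of 72 h (a lower number here means a stronger inhibitor, a higher number a weaker inhibitor), are these
- Compound 1 `CCN(CC)CCNC(=O)c1cc(C(CC)(CC)c2ccc(C#CC(O)(CC)CC)c(C)c2)cn1CC` gives 5350 nM
- Compound 2 `CCn1cc(C(CC)(CC)c2ccc(C#CC(O)(CC)CC)c(C)c2)cc1C(=O)NCCN(C)C` gives 10100 nM
- Compound 3 `CCn1cc(C(CC)(CC)c2ccc(C#CC(O)(CC)CC)c(C)c2)cc1C(=O)NCCC(=O)O` gives > 50000 nM as a limit, not a number

Compound 3 has only a limit, so no number fixes its place: it stands at the limit of > 50000 nM in this assay, at which 1 of the 3 values shown sits, in this series.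

Compound 4 `CCn1cc(C(CC)(CC)c2ccc(C#CC(O)(CC)CC)c(C)c2)cc1C(=O)N[C@@H](C(=O)O)C(C)C` has 1-carboxy-2-methylpropyl in place of 2-carboxyethyl on an amide-type nitrogen, and so it keeps the carboxy group. Among the compounds with values here, two measured steps bear on that group. Carboxy in place of diethylamino gave an at least 9.3-fold higher number from compound 1 to compound 3 (0.97 log units; beyond the scatter) and carboxy in place of dimethylamino gave an at least 4.9-fold higher number from compound 2 to compound 3 (0.69 log units; beyond the scatter) in the same assay. The exchange of the two amines gave a 1.9-fold higher number from compound 1 to compound 2 (0.28 log units; within the scatter) and offers no further guide. Within the data shown here, no measured step alters the chain that carries the carboxy, so the present change has no direct precedent.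

Since compound 4 retains the carboxy that came with an at least 4.9-fold higher number from compound 2 to compound 3 (0.69 log units; beyond the scatter) and with the larger step from the diethylamino compound, no step beyond the scatter is expected in this assay. The estimate means a number no higher from compound 3 to compound 4 (the limit leaves the size open) as an expected step, and a limit rather than a number is the likelier report. For compound 4 the expected value is 50000 nM within an estimated range of 20000 nM to 100000 nM in this assay.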

Compound 4, half-maximal inhibitory concentration: 10300 nM
Compound 4: middle estimate off by 4.9-fold (0.69 log units), on the high side; the measured number lies below the stated range.
By their numbers in this assay, from the lowest: compounds 1, 2 and 4 (each within the scatter of the next). At a limit, above all of these: compound 3.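

Working from this assay, the carboxy group no longer goes with a high number on this amide-type nitrogen: 1-carboxy-2-methylpropyl in place of 2-carboxyethyl gives an at least 4.8-fold lower number from compound 3 to compound 4 (0.68 log units; beyond the scatter). The chain that carries the carboxy therefore matters at this position, and the two amine chains show no separation from the branched acid, with a 1.0-fold higher number from compound 2 to compound 4 (0.01 log units; within the scatter) and a 1.9-fold higher number from compound 1 to compound 4 (0.28 log units; within the scatter), so among the compounds shown only the 2-carboxyethyl chain stands apart. Compound 3 is held as a limit, not a number: the limit of > 50000 nM in this assay, at which 1 of the 4 values shown sits.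

The exchange alters the carboxy chain in more than one way at once, through its branching, the place of the carboxy along the chain and the defined stereocentre, and the compounds shown do not separate these. A carboxymethyl chain without the branch, the same chain with the opposite stereocentre, or a methyl ester in place of the carboxy would each bear on which of these features goes with the lower number.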